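Methyl on the ring nitrogen in a weak inhibitor series

This account rests on a few compounds, and the source may have more. Where it says the series, first, only, none or still open, it means among the compounds named here.

Compound 1 `CN(Cc1ccc(OCCCNC(=N)N)cc1)c1nc2ccc(Oc3ccc(C(F)(F)F)cc3)cc2s1` and compound 2 `N=C(N)NCCCOc1ccc(CNc2nc3ccc(Oc4ccc(C(F)(F)F)cc4)cc3s2)cc1` differ by methyl in place of hydrogen on a nitrogen on an aromatic ring. In an assay on cells for inhibition of Voltage-dependent T-type calcium channel subunit alpha-1H (Homo sapiens), read by FLIPR and calcium flux, with stated times of 600 s and 300 s (on this read-out higher numbers stand for weaker inhibition and lower numbers for stronger inhibition), compound 1 gives 212000 nM, and compound 2 gives 195000 nM; the change amounts to a 1.1-fold higher number from compound 2 to compound 1 (0.04 log units; within the scatter). Compound 3 `CN(C)CCCOc1ccc(CNc2nc3ccc(Oc4ccc(C#N)cc4)cc3s2)cc1` belongs to the same series, but the difference between its core and that of compound 2 is not broken down here. In this assay compound 3 gives 41000 nM, the lowest of the three numbers, with compound 1 and compound 2 both beyond the scatter from it. Compound 4 `CN(C)CCCOc1ccc(CN(C)c2nc3ccc(Oc4ccc(C#N)cc4)cc3s2)cc1` arises from compound 3 by methyl in place of hydrogen on a nitrogen on an aromatic ring, the same change as from compound 2 to compound 1, with the place described in identical words. Because a 1.1-fold higher number from compound 2 to compound 1 (0.04 log units; within the scatter) lay within the scatter, a similarly small step is expected here, a 1.1-fold higher number from compound 3 to compound 4 (0.04 log units; within the scatter). Compound 4 is estimated at 45000 nM, within 20000 nM to 100000 nM.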

Compound 4, half-maximal inhibitory concentration: 64000 nM
Estimate against measurement, compound 4: 1.4-fold (0.15 log units) below; low and high end bracket the measured number.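

Methyl in place of hydrogen on the nitrogen gives a 1.6-fold higher number from compound 3 to compound 4 (0.19 log units; within the scatter) in this assay and so stays small on this core too. Two pairs are too few to show that the step holds on cores beyond these two or in any other read-out. Set side by side, the two steps do not differ: the same change on two cores in this assay, a 1.1-fold higher number (0.04 log units; within the scatter) from compound 2 to compound 1 and a 1.6-fold higher number (0.19 log units; within the scatter) from compound 3 to compound 4, 1.4-fold (0.16 log units) apart, within the scatter of two such steps

Left open is whether a larger group on that nitrogen, such as ethyl or acetyl, would also leave the number within the scatter. Also open, as far as these compounds go, is how the methyl step behaves on a core that ends its chain in a carboxylic acid rather than an amine or guanidine.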